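Swapping a Pyrimidine for a Pyridine on the Sulfonamide

This account rests on a few compounds, and the source may have more. Where it says the series, first, only, none or still open, it means among the compounds named here.

Of the compounds shown here, two have been measured in a functional assay on MCF7 cells (Homo sapiens) for antiproliferative activity, read by sulforhodamine B assay, with a stated time of 72 h; on this read-out higher numbers stand for weaker inhibition and lower numbers for stronger inhibition. Compound 1 `O=S(=O)(Nc1ncccn1)c1ccc(Nc2nncc3ccccc23)cc1` gives 64 nM in this assay. Compound 2 `O=C1CS/C(=N/Nc2nncc3ccccc23)N1` gives 89 nM in this assay. Compound 1 holds the lowest of the two numbers, but its gap to compound 2 lies within the usual scatter, so the two cannot be told apart on these numbers. The new compound, compound 3 `O=S(=O)(Nc1ccccn1)c1ccc(Nc2nncc3ccccc23)cc1`, differs from compound 1 in one place: pyridin-2-yl in place of pyrimidin-2-yl on a sulfonamide nitrogen. Among the measured compounds shown here, no step between measured compounds is available to show how such a change moves the read-out, so the expectation rests on the change itself, which is small and keeps the rest of the molecule intact. For compound 3 the step of a 1.3-fold higher number from compound 1 to compound 3 (0.10 log units; within the scatter) is expected to be small, in no clear direction, and not beyond the scatter. Compound 3 is therefore estimated at 80 nM, with a range from 25 nM to 250 nM.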

Compound 3, half-maximal inhibitory concentration: 53 nM
The estimate for compound 3 lay 1.5-fold (0.18 log units) above the measured number; the range from low to high includes it.
By their numbers in this assay, from the lowest: compounds 3, 1 and 2 (each within the scatter of the next).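

Putting pyridin-2-yl in place of pyrimidin-2-yl on the sulfonamide nitrogen gives a 1.2-fold lower number from compound 1 to compound 3 (0.08 log units; within the scatter) in this assay, so compound 1 and compound 3 cannot be told apart on these numbers. Among the compounds shown here, this is the first direct look at this position: the ring can go from 2 hetero atoms to 1, and from 2 hydrogen-bond acceptors to 1, with no change in the read-out that stands clear of the scatter. Nothing at hand explains why the read-out stays level.

As far as these compounds go, whether the last ring nitrogen matters remains open, and a plain phenyl ring on the sulfonamide nitrogen would test that. So too remains the question of whether this position needs an aromatic six-membered ring at all, which a thiazole or a simple methyl group could address.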